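Adding a Hydroxy Group to Compound 1

The compounds below may be only part of what the source reports. "The series", "measured", "known", "first", "only" and "open" are said of these compounds alone.

- Compound 1 `COc1ccc(CN(C(=O)CSC(=S)N2CCN(C)CC2)c2cc(OC)c(OC)c(OC)c2)cc1`: 1250 nM
- Compound 2 `COc1ccc(CN(C(=O)CSC(=S)N2CCCC2)c2cc(OC)c(OC)c(OC)c2)cc1`: 13800 nM
- Compound 3 `COc1ccc(CN(C(=O)CSC(=S)N2CCc3ccccc3C2)c2cc(OC)c(OC)c(OC)c2)cc1`: > 20000 nM, a limit of the assay

In a functional assay on KYSE-450 cells (Homo sapiens) for inhibition, read by CCK-8 assay, with a stated time of 48 h (a higher number here means a weaker inhibitor, a lower number a stronger inhibitor), compound 1 gives 1250 nM, the lowest number of the set, and its steps to both other compounds lie beyond the scatter. Compound 4 `COc1ccc(CN(C(=O)CSC(=S)N2CCN(C)CC2)c2cc(OC)c(OC)c(OC)c2)cc1O` keeps the core of compound 1 and makes one change: hydroxy in place of hydrogen on an aromatic carbon. This turns 4-methoxybenzyl into 3-hydroxy-4-methoxybenzyl.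

Going by the values given here, all the measured steps sit elsewhere, on the thiocarbonyl carbon. Two were large: an 11-fold higher number from compound 1 to compound 2 (1.04 log units; beyond the scatter) and an at least 16-fold higher number from compound 1 to compound 3 (1.20 log units; beyond the scatter). The third, an at least 1.4-fold higher number from compound 2 to compound 3 (0.16 log units; that floor lies within the scatter), has a floor within the scatter. These steps show that one change can move the numbers in this assay considerably, but none tests a hydroxy group, so they fix neither the size nor the direction of this step. The estimate therefore stays near compound 1, with a wide range. The expected step is a 1.6-fold lower number from compound 1 to compound 4 (0.19 log units; within the scatter). Compound 4 is estimated at 800 nM, with an expected range of 150 nM to 4000 nM.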

Compound 4, half-maximal inhibitory concentration: 760 nM
Compound 4: middle estimate off by 1.1-fold (0.02 log units), on the high side, and the stated range covers the measured number.
By their numbers in this assay, from the lowest: compounds 4 and 1 (each within the scatter of the next); then compound 2. At a limit, above all of these: compound 3.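

In this assay, hydroxy in place of hydrogen on this aromatic carbon gives a 1.6-fold lower number from compound 1 to compound 4 (0.22 log units; within the scatter), so compound 1 and compound 4 cannot be told apart. Going by these compounds alone, the earlier steps all lay on the thiocarbonyl carbon and showed only that changes there can cost a great deal; this is the first reading from the 4-methoxybenzyl side, and here the added hydroxy brings no loss in this assay. Nothing measured here bears on why the number stays within the scatter.

The compounds shown leave open whether an amine, a fluorine atom or a longer ether chain on this same carbon would move the number beyond the scatter. They also leave open whether the 3-hydroxy-4-methoxybenzyl group would behave the same way alongside the pyrrolidin-1-yl group of compound 2.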